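Shifting the Carboxyl Group Around the Phenoxy Ring

The source may report more compounds than this note shows. Statements on the series, on what has been measured and on what is new or still open speak of the compounds shown alone.

Compound 1 `CN(Cc1ccc(C(=O)O)cc1)c1ccc(OCc2c(-c3c(Cl)cccc3Cl)noc2C2CC2)nc1C(F)(F)F` and compound 2 `O=C(O)c1ccccc1OCc1ccc(OCc2c(-c3c(Cl)cccc3Cl)noc2C2CC2)nc1C(F)(F)F` share one core and differ at a single aromatic carbon. In a functional assay on HEK293 cells for agonist activity at Bile acid receptor (Homo sapiens) (a lower number here means a smaller maximal response, a higher number a larger maximal response), compound 1 gives 81%, and compound 2 gives 63%. Within the data shown here, that single exchange produced a number 18 percentage points lower from compound 1 to compound 2 (beyond the scatter), so compound 2 stands as the lower of the two numbers measured in this assay so far.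

Compound 3 `O=C(O)c1cccc(OCc2ccc(OCc3c(-c4c(Cl)cccc4Cl)noc3C3CC3)nc2C(F)(F)F)c1` has not yet been measured. It differs from compound 2 by 3-carboxyphenyl in place of 2-carboxyphenyl on an oxygen on a saturated carbon. Among the measured compounds shown here, the one step measured so far, a number 18 percentage points lower from compound 1 to compound 2 (beyond the scatter), replaced an entire side arm with a different one and therefore tells little about exchanging 2-carboxyphenyl for 3-carboxyphenyl while keeping every atom in place. For the measured compounds named here, no measured step bears directly on this change. With nothing to anchor it, the expected step for compound 3 is a number 5 percentage points higher from compound 2 to compound 3 (within the scatter), which lies inside the scatter, meaning no clear change in either direction is expected. The estimate for compound 3 in this assay is 68%, with a range from 45% to 90%.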

Compound 3, largest response reached (reported as efficacy), in percent of the reference or control that the assay uses: 62%
Compound 3: middle estimate off by 6 percentage points, on the high side, and the stated range covers the measured number.
By their numbers in this assay, from the lowest: compounds 3 and 2 (each within the scatter of the next); then compound 1.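

Moving the carboxylic acid around the ring, from 2-carboxyphenyl to 3-carboxyphenyl on the same oxygen, gives a number 1 percentage points lower from compound 2 to compound 3 (within the scatter) in this assay. Among these compounds, the two compounds hold the same atoms joined differently, so this exchange, which no earlier step could speak to, brings no clear change in maximal response. Exchanging the whole side arm of compound 1 gives much the same picture as before, with a number 19 percentage points lower from compound 1 to compound 3 (beyond the scatter) alongside a number 18 percentage points lower from compound 1 to compound 2 (beyond the scatter), so both (carboxyphenoxy)methyl arms fall short of the (4-carboxybenzyl)(methyl)amino arm, and neither compound goes against this. Nothing measured here gives a reason for either result.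

Still open, from the compounds shown here alone, is whether 4-carboxyphenyl on the same oxygen would stay level with these two compounds, or whether it would come closer to compound 1, whose acid sits on a 4-carboxybenzyl group. The arm of compound 1 also differs from the other two in more than one feature at once, so these compounds cannot separate the effect of its methylamino link from that of its benzyl group, and a simple amine or an ester in place of the carboxylic acid would test how much the acid itself matters.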